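The source may hold more compounds than are shown below. What is called first, only, known or untested is meant among the compounds shown, and "the series" means these compounds.

Measured so far:
- compound 1, `CC(C)N1CC(=O)N=C1N/C(=N/c1ccc(Cl)c(Cl)c1)N1CCCCC1`: 0.467 h
- compound 2, `CN1CC(=O)N=C1NC(=N)Nc1ccc(Cl)c(Cl)c1`: > 1 h

Among the compounds with values here, in an in vivo ADME assay on the whole organism for metabolic stability, with Homo sapiens as the target, read by LC-MS, at a dose of 160 mg/kg by the oral route (a higher number here means that the compound lasts longer, a lower number that the compound disappears faster), compound 1 gives 0.467 h, the only plain number in the set. Compound 2 sits at a limit of the assay, > 1 h, and is a limit rather than a measured number; this is the situation summed up as the limit of > 1 h in this assay, at which 1 of the 2 values shown sits. Within the data shown here, no pair of measured compounds differs in just one place, so no measured step is available to scale a change on the shared core.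

The unmeasured compound 3, `CC(C)N1CC(=O)N=C1N/C(=N/c1ccc(Cl)c(Cl)c1)N1CCCC1`, differs from compound 1 by pyrrolidin-1-yl in place of piperidin-1-yl on a carbon with a double bond to nitrogen. Both rings carry no donors, no acceptors and no charge, and the count differs by one carbon only.

With nothing in the data that speaks to the size of such a change, the step expected in this assay is a 1.2-fold higher number from compound 1 to compound 3 (0.07 log units; within the scatter), which is not beyond the usual scatter. Compound 3 is therefore estimated at 0.55 h, with a range from 0.25 h to 1.2 h, leaving room for a result reported only as a limit.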

Compound 3, half-life: > 1 h
Compound 3: a limit, no number; the forecaster's own chance of this, stated with the estimate: 15%; middle value at least 1.8-fold (0.25 log units) from the limit.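

In this assay, pyrrolidin-1-yl in place of piperidin-1-yl on a carbon with a double bond to nitrogen gives an at least 2.1-fold higher number from compound 1 to compound 3 (0.33 log units; beyond the scatter). Within the data shown here, this is the only one-place comparison so far, and it shows that this position responds to a change of ring size alone, with the counts of donors and acceptors and the net charge the same on both sides. Compound 3 carries a limit and not a number, so the step has a floor but no measured size, and its full extent cannot be read from the data: the limit of > 1 h in this assay, at which 2 of the 3 values shown sit.

The compounds shown leave open whether a morpholin-4-yl or an open-chain diethylamino group at this place would stay with piperidin-1-yl or go with pyrrolidin-1-yl in this assay. They also leave open whether the step holds when the isopropyl group of compound 1 gives way to a cyclopropyl group, and the data offer no reason for the step itself.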